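This account rests on a few compounds, and the source may have more. Where it says the series, first, only, none or still open, it means among the compounds named here.

Compound 3 `CC(C)OC(=O)N1CCC(O[C@H]2CC[C@H](Oc3cnc(S(C)(=O)=O)cn3)CC2)CC1` is the point of departure. In a functional assay on isolated protein for agonist activity at Glucose-dependent insulinotropic receptor (Homo sapiens), read by HTRF and cAMP accumulation (a lower number here means a smaller maximal response, a higher number a larger maximal response), compound 3 gives 110%, the largest of the three numbers that have been obtained, although its gaps to the other two compounds both lie within the usual scatter. Compound 1 `CC(C)(C)OC(=O)N1CCC(O[C@H]2CC[C@H](Oc3ccc(S(C)(=O)=O)c(F)c3)CC2)CC1` gives 106% in this assay, and compound 2 `CC(C)OC(=O)N1CCC(O[C@H]2CC[C@H](Oc3ccc(S(C)(=O)=O)nc3)CC2)CC1` gives 101%. Within the data shown here, the one change between measured compounds that differs in a single place, a number 9 percentage points higher from compound 2 to compound 3 (within the scatter), concerns the aryl group on the oxygen on a saturated carbon and did not move the maximal response beyond the scatter.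

Compound 4 `CS(=O)(=O)c1cnc(O[C@H]2CC[C@H](OC3CCN(C(=O)Oc4ccccc4)CC3)CC2)cn1` differs from compound 3 elsewhere: phenyl in place of isopropyl on an oxygen next to a carbonyl group. Among the measured compounds shown here, no measured pair varies the group on this oxygen alone; compound 1 carries a tert-butyl there while compound 2 and compound 3 carry isopropyl, but those compounds differ in the aryl group as well, so only their values can be set side by side, and they sit within the scatter of one another. For the measured compounds named here, the only single-place step available, a number 9 percentage points higher from compound 2 to compound 3 (within the scatter), lay within the scatter. Compound 4 is therefore expected to show a step of about a number 5 percentage points lower from compound 3 to compound 4 (within the scatter) in this assay, which would not reach beyond the scatter. Compound 4 is estimated to give 105%, between 85% and 120%.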

Compound 4, largest response reached (Emax), in percent of the reference or control that the assay uses: 116%
For compound 4 the middle estimate is 11 percentage points below the measured one, within the range that was stated.
By their numbers in this assay, from the lowest: compounds 2, 1, 3 and 4 (each within the scatter of the next, the first and the last beyond it).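

The step in this assay, a number 6 percentage points higher from compound 3 to compound 4 (within the scatter), is the first single-place change among these compounds at the group on the oxygen next to a carbonyl group; the earlier single-place step concerned only the aryl group at the other end of the molecule. It shows that, with the rest of compound 3 held fixed, phenyl, with 6 heavy atoms and one six-membered aromatic ring of carbon only, can take the place of isopropyl, with 3 heavy atoms and no ring, without the maximal response moving beyond the scatter, though this rests on one pair. No measurement shown here bears on the reason for this outcome.

The compounds shown leave open whether phenyl behaves the same way alongside the aryl groups of compound 1 and compound 2, as the change is seen with only one aryl group. They also leave open how the maximal response would stand with a benzyl group or a pyridin-3-yl group on this oxygen, or with an amine nitrogen in place of the oxygen itself.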